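Swapping an aryl group on a bis-arylidene ketone

The source may hold more compounds than are shown below. What is called first, only, known or untested is meant among the compounds shown, and "the series" means these compounds.

Compound 3 `COc1cc(/C=C2\CCC/C(=C\c3ccc([N+](=O)[O-])cc3)C2=O)ccc1O` gives 7.05 ug/mL in a functional assay on MCF7 cells (Homo sapiens) for cytotoxicity, read by MTT assay; on this read-out higher numbers stand for weaker inhibition and lower numbers for stronger inhibition. Compound 1 `O=C1/C(=C/c2ccc([N+](=O)[O-])cc2)CCC/C1=C\c1cccc([N+](=O)[O-])c1` gives 8.4 ug/mL and compound 2 `COc1cccc(/C=C2\CCC/C(=C\c3ccc([N+](=O)[O-])cc3)C2=O)c1` gives 5.82 ug/mL, so all three numbers sit within the usual scatter of one another. The change to compound 4 `O=C1/C(=C/c2ccc(Cl)cc2)CCC/C1=C\c1ccc([N+](=O)[O-])cc1` is 4-chlorophenyl in place of 4-hydroxy-3-methoxyphenyl on a double-bonded chain carbon bound to a double-bonded ring carbon. For the measured compounds named here, two measured steps touch the same position: a 1.2-fold lower number from compound 1 to compound 3 (0.08 log units; within the scatter) and a 1.2-fold higher number from compound 2 to compound 3 (0.08 log units; within the scatter), both small. Going by the values given here, no measured compound carries a chlorine, so the chloro group itself is untested, but the earlier aryl swaps at this position moved the numbers little. The expected step is therefore a 1.0-fold lower number from compound 3 to compound 4 (0.00 log units; within the scatter), not beyond the scatter. Compound 4 is expected to give about 7 ug/mL, within a range from 3.5 ug/mL to 14 ug/mL.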

Compound 4, half-maximal inhibitory concentration: 1.02 ug/mL
Beside the measured number, compound 4's estimate is 6.9-fold (0.84 log units) above it; measured number outside the range, below it.
By their numbers in this assay, from the lowest: compound 4; then compounds 2, 3 and 1 (each within the scatter of the next).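

In this assay the 4-chlorophenyl group shows that this position can move the number: the steps read a 6.9-fold lower number from compound 3 to compound 4 (0.84 log units; beyond the scatter) and a 5.7-fold lower number from compound 2 to compound 4 (0.76 log units; beyond the scatter) and an 8.2-fold lower number from compound 1 to compound 4 (0.92 log units; beyond the scatter) and all lie beyond the scatter, while the three earlier compounds stayed within the scatter of one another. Compound 4 therefore has the lowest number of the four, which means the strongest inhibition shown here. Nothing measured here explains this gap.

From the compounds shown here alone, whether the step belongs to the chlorine itself stays open. So does what a 4-bromophenyl or 4-aminophenyl group would give at this position.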